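Removing the methoxy from the methoxymethyl side chain

The source may hold more compounds than are shown below. What is called first, only, known or untested is meant among the compounds shown, and "the series" means these compounds.

Measured compounds in a functional assay on HEK293 cells for antagonist activity at corticotropin-releasing factor receptor 1 (Homo sapiens), read by fluorescence and cAMP accumulation, with a stated time of 30 min; a lower number here means a stronger inhibitor, a higher number a weaker inhibitor:
compound 1, `COCc1cc(OC)c(-c2cccc3c(N(CC4CCOCC4)CC4CC4)c(SC)nn23)c(OC)c1`, 30 nM
compound 2, `COCc1cc(OC)c(-c2cccc3c(N(CC4CCOCC4)CC4CC4)c(OC)nn23)c(OC)c1`, 110 nM
compound 3, `CCc1nn2c(-c3c(OC)cc(COC)cc3OC)cccc2c1N(CC1CCOCC1)CC1CC1`, 23 nM

Compound 3 gives the lowest of the three numbers in this assay, though compound 1 stands within the scatter of it, so the two cannot be ranked. Compound 2 stands further away: a 4.8-fold lower number from compound 2 to compound 3 (0.68 log units; beyond the scatter).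

Compound 4, `CCc1nn2c(-c3c(OC)cc(C)cc3OC)cccc2c1N(CC1CCOCC1)CC1CC1`, is not yet measured. It differs from compound 3 in one place: hydrogen in place of methoxy on a saturated chain carbon bound to an aromatic carbon. Every measured step concerns the group on the aromatic carbon of the shared core, as in a 3.7-fold higher number from compound 1 to compound 2 (0.56 log units; beyond the scatter) and a 1.3-fold lower number from compound 1 to compound 3 (0.12 log units; within the scatter); none touches the side chain on the outer ring. Among the measured compounds shown here, no measured step therefore bears on this change, and nothing here points in either direction. The expected step in this assay from compound 3 to compound 4 is none beyond the scatter, a 1.1-fold higher number from compound 3 to compound 4 (0.04 log units; within the scatter). For the measured compounds named here, compound 4 is estimated to give about 25 nM in this assay, expected to fall between 8 nM and 80 nM, with a wide range because no step reaches this position.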

Compound 4, half-maximal inhibitory concentration: 20 nM
Compound 4: the middle estimate sits 1.3-fold (0.10 log units) above what was measured; the measured number falls inside the stated range.
By their numbers in this assay, from the lowest: compounds 4, 3 and 1 (each within the scatter of the next); then compound 2.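

In this assay, the first change shown on the side chain of the outer ring gives a 1.2-fold lower number from compound 3 to compound 4 (0.06 log units; within the scatter), which lies within the scatter. Going from methoxymethyl to methyl removes methoxy and its one hydrogen-bond acceptor, yet the compounds cannot be told apart here, so with ethyl on the shared core this group can go without a measurable penalty, whereas two of the earlier steps on the core carbon went beyond the scatter. Nothing available explains why this position shows no step.

The compounds shown leave open whether the same holds with methylsulfanyl or methoxy on the core. They also do not say how this carbon would respond to an amine, a carboxylic acid or a longer ether chain in place of the methoxy.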